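The source may report more compounds than this note shows. Statements on the series, on what has been measured and on what is new or still open speak of the compounds shown alone.

Measured so far in an assay on isolated protein for inhibition of histone deacetylase 8 (Homo sapiens), with a stated time of 15 min; on this read-out higher numbers stand for weaker inhibition and lower numbers for stronger inhibition: compound 1 `Nc1ncnc2c1c(-c1cnc3[nH]ccc3c1)nn2CCCCCCCCC(=O)NO` gives 733 nM; compound 2 `CNC(=O)CCCCCCCn1nc(-c2ccc3oc(N)nc3c2)c2c(N)ncnc21` gives 334 nM.

Compound 2 holds the lower of these two numbers, and the gap to compound 1 lies beyond the usual scatter of this assay.

Compound 3 `Nc1nc2cc(-c3nn(CCCCCCC(=O)NO)c4ncnc(N)c34)ccc2o1` differs from compound 2 in a single place: hydroxycarbamoyl in place of (methylcarbamoyl)methyl on a saturated chain carbon, six bonds along the chain from an aromatic nitrogen. For the measured compounds named here, no measured pair shows this exact change, so its size is not known from the data. Compound 3 is nonetheless expected to show a step toward a lower number, of size a 2.2-fold lower number from compound 2 to compound 3 (0.35 log units; beyond the scatter), somewhat beyond the scatter. Compound 3 is estimated at 150 nM, with a range from 40 nM to 600 nM.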

Compound 3, half-maximal inhibitory concentration: 231 nM
Estimate against measurement, compound 3: 1.5-fold (0.19 log units) below; the measured number falls inside the stated range.
By their numbers in this assay, from the lowest: compounds 3 and 2 (each within the scatter of the next); then compound 1.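

In this assay, putting hydroxycarbamoyl in place of (methylcarbamoyl)methyl on this saturated chain carbon gives a 1.4-fold lower number from compound 2 to compound 3 (0.16 log units; within the scatter). So this first look at the position shows that the exchange, with four heavy atoms entering and five leaving, does not separate the two compounds on this read-out. Nothing measured here offers an explanation for this result. Still open, as far as these compounds go, is how other groups at this chain position would compare, such as a carboxylic acid, a methyl ester or an unsubstituted amide.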